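Ring Growth and an Amide at the Amino Substituent

The compounds below may be only part of what the source reports. "The series", "measured", "known", "first", "only" and "open" are said of these compounds alone.

The series shares one core, seen in compound 1 `N#Cc1cnc(NCc2cnccc2C(F)(F)F)cc1N[C@H]1C[C@@H](O)C1` and compound 2 `N#Cc1cnc(NCc2cnccc2C(F)(F)F)cc1N[C@H]1CC[C@H](O)CC1`. Both were tested in an assay on isolated protein for inhibition of protein kinase C theta type (Homo sapiens), read by TR-FRET, with a stated time of 2 h; a higher number here means a weaker inhibitor, a lower number a stronger inhibitor. In this assay compound 1 gives 500 nM, and compound 2 gives 350 nM. Going by the values given here, the only measured step is a 1.4-fold lower number from compound 1 to compound 2 (0.15 log units; within the scatter), so compound 1 has the highest number of the two, but its nearest neighbour, compound 2, lies within the scatter of it, and no order between them can be read from these numbers.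

Compound 3 `N#Cc1cnc(NCc2cnccc2C(F)(F)F)cc1N[C@H]1CC[C@@H](C(N)=O)CC1` has not been measured in this assay. Its change from compound 1 is 4-carbamoylcyclohexyl in place of 3-hydroxycyclobutyl on a nitrogen on an aromatic ring. The step from compound 1 to compound 2 bears on part of it, since it also exchanges a four-membered ring for a six-membered one, and it was within the scatter. Among the compounds with values here, no measured pair shows the effect of a carbamoyl in place of a hydroxyl, so that part stays open.

Compound 3 is therefore expected to show a step of a 1.3-fold lower number from compound 1 to compound 3 (0.10 log units; within the scatter) in this assay, within the scatter, with no direction implied. The estimate for compound 3 in this assay is 400 nM, with a range from 120 nM to 1300 nM.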

Compound 3, half-maximal inhibitory concentration: 7 nM
The estimate for compound 3 lay 57-fold (1.76 log units) above the measured number; measured number outside the range, below it.
By their numbers in this assay, from the lowest: compound 3; then compounds 2 and 1 (each within the scatter of the next).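

In this assay, the substituent on this nitrogen turns out to matter strongly: with the six-membered ring kept, 4-carbamoylcyclohexyl in place of 4-hydroxycyclohexyl gives a large step (a 50-fold lower number from compound 2 to compound 3 (1.70 log units; beyond the scatter)), which is beyond the scatter. The full change from 3-hydroxycyclobutyl to 4-carbamoylcyclohexyl is of similar size (a 71-fold lower number from compound 1 to compound 3 (1.85 log units; beyond the scatter)), whereas the ring change with the hydroxyl retained stayed within the scatter (a 1.4-fold lower number from compound 1 to compound 2 (0.15 log units; within the scatter)), so these three compounds place the gain with the carbamoyl on the six-membered ring and not with the larger ring alone. Nothing available explains why the carbamoyl has an effect of this size.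

The compounds shown leave open whether a carbamoyl on the cyclobutyl ring would give a similar step, which would show whether the amide depends on the six-membered ring. They also leave open how a carboxylic acid, an amine or an amide carrying a methyl on its nitrogen would compare with the carbamoyl at the same place on the ring.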